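A few compounds are considered here, and "the series" means these few. Any claim that something is new, unique, unknown or untested is made for them only; others in the source may bear on it.

Among the measured compounds shown here, compound 1, `O=C(Nc1ccccc1C(F)(F)F)C1CCc2ccccc2N1C(=O)c1cccc(Cl)c1`, gives 292 nM in a functional assay on NCI-H23 cells (Homo sapiens) for cytotoxicity, read by sulforhodamine B assay, with a stated time of 72 h (a higher number here means a weaker inhibitor of growth, a lower number a stronger inhibitor of growth), the only numerical value in this set. Compound 2, `CCCC(=O)N1c2ccccc2CCC1C(=O)Nc1ccccc1C(F)(F)F`, registers only a limit of the assay, > 70000 nM. For the measured compounds named here, the change an at least 230-fold higher number from compound 1 to compound 2 (2.37 log units; beyond the scatter) is the one measured step, and it is explained by nothing beyond the fact that compound 2 sits at the limit of > 70000 nM in this assay, at which 1 of the 2 values shown sits. Going by the values given here, compound 3, `O=C(Nc1ccccc1O)C1CCc2ccccc2N1C(=O)c1cccc(Cl)c1`, differs from compound 1 by hydroxy in place of trifluoromethyl on an aromatic carbon, a change at the anilide end of the molecule rather than at the carbonyl carbon where the single measured step lies. Among the compounds with values here, that step therefore does not bear directly on the change to compound 3, and no measured pair informs the swap of trifluoromethyl for hydroxy. The expectation for compound 3 is a modest weakening, expressed as the step of a 5.1-fold higher number from compound 1 to compound 3 (0.71 log units; beyond the scatter). Compound 3 is accordingly estimated at 1500 nM in this assay, within a wide range of 200 nM to 15000 nM.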

Compound 3, concentration for 50% growth inhibition: 11600 nM
Compound 3: middle estimate off by 7.7-fold (0.89 log units), on the low side, within the range that was stated.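

The earlier compounds shown here showed a large change only at the carbonyl carbon, whereas this result shows that the aromatic carbon ortho to a large group also responds strongly, with 2-hydroxyphenyl in place of 2-(trifluoromethyl)phenyl giving a 40-fold higher number from compound 1 to compound 3 (1.60 log units; beyond the scatter) in this assay as a numerical step and not as a limit. Among the compounds shown here, this single pair exchanges trifluoromethyl for hydroxy, so it cannot separate the loss of the one group from the gain of the other. Nothing measured on either group bears on this result, and the step stands without a stated cause.

On these data alone, whether an amine, a methoxy group or a single fluorine on this aromatic carbon would give a number nearer that of compound 1 or that of compound 3 stays open. Also open, as far as these compounds go, is whether a carboxylic acid here would weaken growth inhibition further.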